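A new group on the sulfonamide nitrogen of compound 2

The source may report more compounds than this note shows. Statements on the series, on what has been measured and on what is new or still open speak of the compounds shown alone.

Measured in a functional assay on cells (leukaemia cell line, Homo sapiens) for inhibition, read by sulforhodamine B assay, with a stated time of 48 h; a lower number here means a stronger inhibitor of growth, a higher number a weaker inhibitor of growth:
- compound 1 `O=S(=O)(Nc1ccc(Cl)c(F)c1)c1ccc(-c2cnc(C3CC3)o2)cc1`: 380 nM
- compound 2 `Cc1cc(Cl)ccc1NS(=O)(=O)c1ccc(-c2cnc(C3CC3)o2)cc1`: 277 nM

Compound 2, at 277 nM, stands level with compound 1, at 380 nM, within the scatter of this assay. Neither can be ranked ahead of the other on these numbers. The unmeasured compound 3 `Cc1cc(F)cc(NS(=O)(=O)c2ccc(-c3cnc(C4CC4)o3)cc2)c1` keeps the shared core and alters the group on the sulfonamide nitrogen: 3-fluoro-5-methylphenyl in place of 4-chloro-2-methylphenyl (3-fluoro-5-methylphenyl in place of 4-chloro-2-methylphenyl on a sulfonamide nitrogen).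

For the measured compounds named here, no measured step contains this exact exchange. The only one that bears on it is a 1.4-fold lower number from compound 1 to compound 2 (0.14 log units; within the scatter), which also alters the group on that nitrogen and stays within the scatter. A single step is thin ground, and it gives no firm direction. No large shift in this assay is therefore expected, only a difference that the scatter could hide.

The step expected is a 1.2-fold higher number from compound 2 to compound 3 (0.06 log units; within the scatter).

Compound 3 is estimated at 320 nM, with an expected range of 130 nM to 800 nM.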

Compound 3, concentration for 50% growth inhibition: 138 nM
Estimate against measurement, compound 3: 2.3-fold (0.37 log units) above, and the stated range covers the measured number.
By their numbers in this assay, from the lowest: compounds 3, 2 and 1 (each within the scatter of the next, the first and the last beyond it).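

In this assay, the group on the sulfonamide nitrogen now yields its first step beyond the scatter: a 2.8-fold lower number from compound 1 to compound 3 (0.44 log units; beyond the scatter), with 3-fluoro-5-methylphenyl in place of 4-chloro-3-fluorophenyl. The exchange of 4-chloro-2-methylphenyl for that same group gives a 2.0-fold lower number from compound 2 to compound 3 (0.30 log units; within the scatter), so only compound 1 and compound 3 can be told apart, and the position is shown to accept all three substituted phenyl groups within a modest span of numbers. Nothing available explains either step.

From the compounds shown here alone, all three groups on this nitrogen are phenyl rings carrying only halogen and methyl substituents, so it remains open how the number would respond to an amine, a carboxylic acid or a methoxy group on that ring. Going by these compounds, it also remains open whether the separation of compound 3 from compound 1 follows from the fluoro group, the methyl group or the two together, and whether that separation would hold with any change to the shared core.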